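The source may hold more compounds than are shown below. What is called first, only, known or untested is meant among the compounds shown, and "the series" means these compounds.

Values so far in an ADME assay on L6 cells (Rattus norvegicus) for cytotoxicity, read by resazurin assay, with a stated time of 72 h (on this read-out higher numbers stand for weaker inhibition and lower numbers for stronger inhibition), are these:
- compound 1 `CN(C)C12CC(c3ccccc3)C(CN(C(=O)CN3CCCCC3)C1)C(c1ccccc1)C2` gives 12100 nM
- compound 2 `CN(C)C12CC(c3ccccc3)C(CN(C(=O)CN3CCCC3)C1)C(c1ccccc1)C2` gives 12600 nM
- compound 3 `CN1CCN(CC(=O)N2CC3C(c4ccccc4)CC(N(C)C)(CC3c3ccccc3)C2)CC1` gives 9250 nM

Compound 3 does not stand apart from the other two. Side by side, the three numbers form one group, with a 1.0-fold higher number from compound 1 to compound 2 (0.02 log units; within the scatter) as well as a 1.3-fold lower number from compound 1 to compound 3 (0.12 log units; within the scatter) and a 1.4-fold lower number from compound 2 to compound 3 (0.13 log units; within the scatter) on record. Each of these steps swaps one ring group for another on a saturated chain carbon bound to a carbonyl carbon, while the shared core stays the same.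

Compound 4 `CN1CCN(CCC(=O)N2CC3C(c4ccccc4)CC(N(C)C)(CC3c3ccccc3)C2)CC1` differs from compound 3 in one place ((4-methylpiperazin-1-yl)methyl in place of 4-methylpiperazin-1-yl on a saturated chain carbon bound to a carbonyl carbon). It carries (4-methylpiperazin-1-yl)methyl in place of 4-methylpiperazin-1-yl on a saturated chain carbon bound to a carbonyl carbon. Going by the values given here, no measured step makes this kind of change to the chain, so the available steps are only an indirect guide. Even so, ring swaps at this same place stayed small, as a 1.4-fold lower number from compound 2 to compound 3 (0.13 log units; within the scatter) shows, so no step beyond the scatter is expected in this assay and no direction can be called. The estimated step is a 1.1-fold higher number from compound 3 to compound 4 (0.03 log units; within the scatter) and is expected to lie within the scatter. The estimated value for compound 4 is 10000 nM with an expected range from 5000 nM to 20000 nM in this read-out.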

Compound 4, half-maximal inhibitory concentration: 13000 nM
The estimate for compound 4 lay 1.3-fold (0.11 log units) below the measured number; the measured number falls inside the stated range.
By their numbers in this assay, from the lowest: compounds 3, 1, 2 and 4 (each within the scatter of the next).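

In this assay the chain that carries the ring can be lengthened at this place with (4-methylpiperazin-1-yl)methyl in place of 4-methylpiperazin-1-yl and give only a 1.4-fold higher number from compound 3 to compound 4 (0.15 log units; within the scatter) and so the tolerance seen so far for ring swaps now extends to a change in the chain itself. The longer chain also stays level with the two compounds that differ from it in both ring and chain length, with a 1.0-fold higher number from compound 2 to compound 4 (0.01 log units; within the scatter) and with a 1.1-fold higher number from compound 1 to compound 4 (0.03 log units; within the scatter) as the printed steps, so all four compounds on a saturated chain carbon bound to a carbonyl carbon still form one group in this cell-toxicity read-out. No supporting measurement accompanies these numbers to account for this flat picture.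

Every group shown at this place ends in a ring containing nitrogen, so it remains open whether an open-chain amine such as dimethylamino, a carboxylic acid or a still longer chain such as 3-(4-methylpiperazin-1-yl)propyl would leave the number just as unmoved. The longer chain also appears here only with the 4-methylpiperazin-1-yl ring, which leaves open how piperidin-1-yl or pyrrolidin-1-yl would behave on it.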